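The source may hold more compounds than are shown below. What is called first, only, known or untested is meant among the compounds shown, and "the series" means these compounds.

Measured compounds in a functional assay on A549 cells (Homo sapiens) for antiproliferative activity, read by MTT assay, with a stated time of 72 h; a lower number here means a stronger inhibitor, a higher number a weaker inhibitor:

Compound 1 `CC(=O)N(C)c1ccc2[nH]c(-c3n[nH]c4ccccc34)cc2n1` gives only a limit, > 50000 nM.
Compound 2 `COc1cccc(C(=O)N(C)c2ccc3[nH]c(-c4n[nH]c5ccccc45)cc3n2)c1` gives 14900 nM.
Compound 3 `CN(c1ccc2[nH]c(-c3n[nH]c4ccccc34)cc2n1)S(=O)(=O)c1ccccc1` gives 14000 nM.

Compound 3 holds the lowest of the two numbers shown; compound 2 sits a step of a 1.1-fold lower number from compound 2 to compound 3 (0.03 log units; within the scatter) away, which is within the scatter, and compound 1 contributes a limit rather than a number (the limit of > 50000 nM in this assay, at which 1 of the 3 values shown sits). The step to compound 4 `CN(C(=O)Nc1ccccc1)c1ccc2[nH]c(-c3n[nH]c4ccccc34)cc2n1` is phenylcarbamoyl in place of phenylsulfonyl on a nitrogen on an aromatic ring. Among the measured compounds shown here, two measured steps bear on it. The exchange of acetyl for phenylsulfonyl gave an at least 3.5-fold lower number from compound 1 to compound 3 (0.55 log units; beyond the scatter), and of methyl for 3-methoxyphenyl on a carbonyl carbon gave an at least 3.3-fold lower number from compound 1 to compound 2 (0.52 log units; beyond the scatter); both steps introduce a phenyl ring, which compound 4 keeps. The swap between the two ring-bearing groups, (3-methoxyphenyl)carbonyl to phenylsulfonyl, gave a 1.1-fold lower number from compound 2 to compound 3 (0.03 log units; within the scatter), within the scatter. Compound 4 keeps a phenyl on the nitrogen and changes only the linking group, so no step beyond the scatter is expected in this assay: no change at the digits printed from compound 3 to compound 4 (within the scatter). Compound 4 is therefore estimated at 14000 nM, with a range from 5000 nM to 40000 nM.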

Compound 4, half-maximal inhibitory concentration: 1430 nM
For compound 4 the middle estimate is 9.8-fold (0.99 log units) above the measured one; measured number below the stated range.
By their numbers in this assay, from the lowest: compound 4; then compounds 3 and 2 (each within the scatter of the next). At a limit, above all of these: compound 1.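

In this assay the linking group on the nitrogen matters even when a phenyl ring is kept: phenylcarbamoyl in place of phenylsulfonyl gives a clear gain (a 9.8-fold lower number from compound 3 to compound 4 (0.99 log units; beyond the scatter)), and anilino in place of 3-methoxyphenyl on the carbonyl carbon gives a similar one (a 10-fold lower number from compound 2 to compound 4 (1.02 log units; beyond the scatter)). Among the compounds shown here, the earlier exchange of (3-methoxyphenyl)carbonyl for phenylsulfonyl had stayed within the scatter, so phenylcarbamoyl, the only one of these groups carrying a hydrogen-bond donor, is the first to separate from the other ring-bearing groups. Anilino in place of methyl on the carbonyl carbon also gives a step (an at least 34-fold lower number from compound 1 to compound 4 (1.54 log units; beyond the scatter)), but it starts from a limit rather than a number: (the limit of > 50000 nM in this assay, at which 1 of the 4 values shown sits).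

On these data alone, whether the amide hydrogen of the anilino group is required remains open, and an N-methylanilino group would test this directly. As far as these compounds go, the effect of a methoxy group or a halogen on the anilino ring, or of a benzylamino group, also remains unknown.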